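Replacing dimethylamino: expected stability of compound 4

A few compounds are considered here, and "the series" means these few. Any claim that something is new, unique, unknown or untested is made for them only; others in the source may bear on it.

Measured in an ADME assay on microsomes from liver (Homo sapiens) for metabolic stability, with a stated time of 60 min, tested at 1 uM; on this read-out lower numbers stand for a less stable compound and higher numbers for a more stable compound:
- compound 1 `COc1cc(-c2cnn3cc(OC)c(-c4cc(C)no4)nc23)ccn1`: 31%
- compound 2 `COc1cc(-c2cnn3cc(OC)c(C(C)(C)O)nc23)ccn1`: 66%
- compound 3 `COc1cc(-c2cnn3cc(OC)c(N(C)C)nc23)ccn1`: 16%

Compound 3 stands lowest of the three measured compounds, with compound 1 nearest to it and compound 2 furthest away. The next compound to consider is compound 4 `COc1cc(-c2cnn3cc(OC)c([C@H]4COC(C)(C)C4)nc23)ccn1`. The change is a group of 7 heavy atoms (6 carbon, 1 oxygen; one five-membered non-aromatic ring with 1 hetero atom) in place of a group of 3 heavy atoms (2 carbon, 1 nitrogen; no ring), on an aromatic carbon. The entering group has no common name and carries 1 defined stereocentre.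

All three measured steps involve this same place on the shared core. Two bear most directly on the change. They end on dimethylamino: a number 15 percentage points lower from compound 1 to compound 3 (beyond the scatter) is modest, and a number 50 percentage points lower from compound 2 to compound 3 (beyond the scatter) is large. Among these compounds, both other groups give a higher number than dimethylamino. The remaining step, a number 35 percentage points higher from compound 1 to compound 2 (beyond the scatter), shows how widely the number moves with the group at this place. Going by the values given here, none of the measured compounds carries the entering ring, so no measured step tests it directly.

A step upward in this assay is therefore expected, of a size between the modest and the large measured steps. The estimated change is a number 29 percentage points higher from compound 3 to compound 4 (beyond the scatter). For compound 4 the expected value is 45%, with an estimated range of 22% to 70%.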

Compound 4, percent of the compound remaining: 21%
Beside the measured number, compound 4's estimate is 24 percentage points above it, outside the stated range (below it).
By their numbers in this assay, from the lowest: compounds 3, 4 and 1 (each within the scatter of the next, the first and the last beyond it); then compound 2.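

In this assay the five-membered non-aromatic ring gives a number 5 percentage points higher from compound 3 to compound 4 (within the scatter) and so no readable gain over dimethylamino, while the comparison with 3-methyl-1,2-oxazol-5-yl gives a number 10 percentage points lower from compound 1 to compound 4 (within the scatter) and likewise separates neither group from the ring. Against 1-hydroxy-1-methylethyl the picture is different, with a number 45 percentage points lower from compound 2 to compound 4 (beyond the scatter) and this leaves compound 2 alone at the top of the four, its group the only one here that carries a hydroxy. A larger group with a ring therefore does not by itself raise the number at this position, since the entering ring has more heavy atoms than 1-hydroxy-1-methylethyl and still falls well short of it.

No measured information accounts for these differences. From the compounds shown here alone, it remains open whether the hydroxy or the branched carbon matters more in compound 2, a question that tert-butyl or hydroxymethyl at this place would address, and what the opposite stereocentre of the entering ring would give.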